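Benzoxazole-free account: a basic side chain is moved and lengthened

A few compounds are considered here, and "the series" means these few. Any claim that something is new, unique, unknown or untested is made for them only; others in the source may bear on it.

Compounds measured so far:
compound 1 `CCN1CCC(Oc2ccc(-c3nc4ccc(Oc5ccc(Cl)cc5)cc4o3)cc2)CC1`: 15.3%
compound 2 `CCN1CCC(COc2ccc(-c3nc4ccc(Oc5ccc(Cl)cc5)cc4o3)cc2)CC1`: 2.1%

In an assay on isolated protein for inhibition of advanced glycosylation end product-specific receptor (Homo sapiens), read by FRET, with stated times of 30 min and 1 h, tested at 4 uM (a higher number here means more inhibition at the concentration tested (going by the name of the read-out), a lower number less inhibition), compound 1 gives 15.3% and stands highest of the two numbers. Its nearest neighbour on this scale is compound 2, which gives 2.1%. Going by the values given here, the single measured step between them, a number 13.2 percentage points lower from compound 1 to compound 2 (beyond the scatter), is the only comparison available, and it runs in the lowering direction when the side chain on the oxygen on the aromatic ring is extended by one carbon.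

Compound 3 `N[C@@H]1CCN(CCCOc2ccc(-c3nc4ccc(Oc5ccc(Cl)cc5)cc4o3)cc2)C1` is not yet measured. It differs from compound 1 in 3-(3-aminopyrrolidin-1-yl)propyl in place of 1-ethylpiperidin-4-yl on an oxygen on an aromatic ring. The step from compound 1 to compound 2 bears on this change only in part: it shows that lengthening the linker between the oxygen and the ring lowered the read-out beyond the scatter, and compound 3 lengthens the linker further while also exchanging the ring and adding a donor. A step downward is therefore expected, of the order of a number 10.3 percentage points lower from compound 1 to compound 3 (beyond the scatter). For compound 3 the estimate in this assay is 5%, within a range from -6% to 17%.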

Compound 3, a percentage reported as inhibition, at one concentration (the size of the read-out at that concentration, not a potency): 19.6%
Beside the measured number, compound 3's estimate is 14.6 percentage points below it; the whole stated range lies below it.
By their numbers in this assay, from the lowest: compound 2; then compounds 1 and 3 (each within the scatter of the next).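

In this assay, replacing 1-ethylpiperidin-4-yl with 3-(3-aminopyrrolidin-1-yl)propyl on an oxygen on an aromatic ring gives a number 4.3 percentage points higher from compound 1 to compound 3 (within the scatter), so this position accepts a five-membered ring, a longer chain and an added hydrogen-bond donor with no change that stands out from the scatter. The comparison with compound 2 gives a number 17.5 percentage points higher from compound 2 to compound 3 (beyond the scatter), and compound 3 therefore goes against any reading of the first pair as a general fall in the number with a longer link on the oxygen. No supporting evidence is available to explain either step.

The ring, the chain and the amine change together in compound 3, so the compounds shown leave open which of them separates it from compound 2, a question that a plain 3-(pyrrolidin-1-yl)propyl group without the amine, or a carboxylic acid in place of the amine, would help to address. From the compounds shown here alone, the opposite configuration at the defined stereocentre also remains open, as does whether any group at this position can lift the inhibition in this assay clearly beyond that of compound 1.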